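Swapping a Halogenated Benzyl Ether in a Cytotoxicity Series

The compounds below may be only part of what the source reports. "The series", "measured", "known", "first", "only" and "open" are said of these compounds alone.

Measured so far:
compound 1 `CCOC(=O)N1[C@@H]2C=C[C@@](OC)(C(=O)c3c2cc(OC)c(OC)c3OCc2ccccc2F)N1C(=O)OCC` — 99.7 ug/mL
compound 2 `COC(=O)N1[C@@H]2C=C[C@@](OC)(C(=O)c3c2cc(OC)c(OC)c3OCc2ccccc2F)N1C(=O)OC` — 137 ug/mL
compound 3 `COC(=O)N1[C@@H]2C=C[C@@](OC)(C(=O)c3c2cc(OC)c(OC)c3OCc2ccc(Cl)cc2)N1C(=O)OC` — 55.9 ug/mL

All three were tested in an ADME assay on KB cells (Homo sapiens) for cytotoxicity; a lower number here means that less compound is needed, a higher number that more compound is needed for the effect. Compound 2 and compound 3 share a core and differ by one change, (4-chlorophenyl in place of 2-fluorophenyl on a saturated chain carbon bound to an oxygen on an aromatic ring), which produced a 2.5-fold lower number from compound 2 to compound 3 (0.39 log units; beyond the scatter). Compound 1 carries a different core from compound 2; the difference between the two cores is not broken down here, and their values in this assay lie within the usual scatter of each other.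

Compound 4 `CCOC(=O)N1[C@@H]2C=C[C@@](OC)(C(=O)c3c2cc(OC)c(OC)c3OCc2ccc(Cl)cc2)N1C(=O)OCC` has not yet been measured. It arises from compound 1 by 4-chlorophenyl in place of 2-fluorophenyl on a saturated chain carbon bound to an oxygen on an aromatic ring, the same change that turned compound 2 into compound 3 at the same place. If that step carries over to the core of compound 1, the expected step is a 2.5-fold lower number from compound 1 to compound 4 (0.40 log units; beyond the scatter), resting on a 2.5-fold lower number from compound 2 to compound 3 (0.39 log units; beyond the scatter). Compound 4 is therefore estimated at 40 ug/mL, with a range from 20 ug/mL to 85 ug/mL.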

Compound 4, concentration for half-maximal effect: 99.9 ug/mL
The estimate for compound 4 lay 2.5-fold (0.40 log units) below the measured number, and the stated range ends below it.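

On the core of compound 1, 4-chlorophenyl in place of 2-fluorophenyl gives a 1.0-fold higher number from compound 1 to compound 4 (0.00 log units; within the scatter) in this assay. Set beside the same change on the other core, the two steps cannot be told apart: the same change on two cores in this assay, a 2.5-fold lower number (0.39 log units; beyond the scatter) from compound 2 to compound 3 and a 1.0-fold higher number (0.00 log units; within the scatter) from compound 1 to compound 4, 2.5-fold (0.39 log units) apart, within the scatter of two such steps. For the compounds shown here, this does not show that the change carries over between the cores, nor that its size depends on the core, as each core offers only one step.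

The compounds shown leave open how a benzyl group without a halogen, or one carrying an amine or a carboxylic acid, would read in this assay. They also leave open how much of any step belongs to the type of halogen and how much to where it sits, as both differ together here.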